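This account rests on a few compounds, and the source may have more. Where it says the series, first, only, none or still open, it means among the compounds named here.

Measured in a functional assay on SK-MEL-28 cells (Homo sapiens) for inhibition, read by MTT assay; on this read-out higher numbers stand for weaker inhibition and lower numbers for stronger inhibition:

- compound 1 `CCCCCCCCCCCC(=O)OC1=C(CC=C(C)C)C(=O)c2ccccc2C1=O`: 18000 nM
- compound 2 `CCCCCCCCCCCCCC(=O)OC1=C(CC=C(C)C)C(=O)c2ccccc2C1=O`: 50000 nM

Only these two compounds have been measured, so the series offers very little to go on. Compound 2, at 50000 nM, carries the higher of the two numbers and is therefore the weaker inhibitor of the pair. Its nearest and only neighbour is compound 1, at 18000 nM.

The next compound to be tested is compound 3 `CCCCCCCCCCCCCCCC(=O)OC1=C(CC=C(C)C)C(=O)c2ccccc2C1=O`. Its structural change from compound 2 is ethyl in place of hydrogen on a saturated chain carbon, ten or more bonds along the chain from a carbonyl carbon. Within the data shown here, one measured step bears on this: a 2.8-fold higher number from compound 1 to compound 2 (0.44 log units; beyond the scatter). That step is the same structural change, ethyl in place of hydrogen on a saturated chain carbon, and it is modest but beyond the scatter. A single step cannot establish a trend, but it points towards a further modest loss of inhibition in this assay, of similar size and in the same direction. The expected step is a 2.2-fold higher number from compound 2 to compound 3 (0.34 log units; beyond the scatter). For compound 3 the estimated value is 110000 nM, with an expected range from 40000 nM to 300000 nM.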

Compound 3, half-maximal inhibitory concentration: 33000 nM
Beside the measured number, compound 3's estimate is 3.3-fold (0.52 log units) above it; measured number below the stated range.
By their numbers in this assay, from the lowest: compounds 1, 3 and 2 (each within the scatter of the next, the first and the last beyond it).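

In this assay, the same change of ethyl in place of hydrogen on a saturated chain carbon, ten or more bonds along the chain from a carbonyl carbon, gives a 1.5-fold lower number from compound 2 to compound 3 (0.18 log units; within the scatter), whereas it gave a 2.8-fold higher number from compound 1 to compound 2 (0.44 log units; beyond the scatter) in the step before, so the weakening of inhibition does not continue steadily along these three compounds, and compound 3 is the one that goes against such a pattern. Taken as a single change, butyl in place of hydrogen at this place gives a 1.8-fold higher number from compound 1 to compound 3 (0.26 log units; within the scatter), which leaves the two ends of the series inseparable on this read-out, and only compound 1 and compound 2 stand apart beyond the scatter. No supporting measurement is available to account for this behaviour at the chain.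

Going by these compounds, whether a longer chain at this place would stay within the scatter of compound 3 remains open. Also open, on these data alone, is what an amine or a carboxylic acid would do in place of the ethyl, and how any of these chains would behave on a changed core.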